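Swapping the Ring on a Sulfonamide Nitrogen and Cytotoxicity

The compounds below may be only part of what the source reports. "The series", "measured", "known", "first", "only" and "open" are said of these compounds alone.

Of the compounds shown here, three have been measured in a functional assay on A549 cells (Homo sapiens) for cytotoxicity, read by sulforhodamine B assay, with a stated time of 72 h; a lower number here means a stronger inhibitor, a higher number a weaker inhibitor. Compound 1 `O=C1/C(=C/c2coc3ccccc3c2=O)N=C(c2ccccc2)N1c1ccc(S(=O)(=O)Nc2nccs2)cc1` gives 88400 nM, compound 3 `O=C1/C(=C/c2coc3ccccc3c2=O)N=C(c2ccccc2)N1c1ccc(S(=O)(=O)Nc2ncccn2)cc1` gives 40500 nM, and compound 2 `O=c1c(CNc2ccc(S(=O)(=O)Nc3ncccn3)cc2)coc2ccccc12` gives 85300 nM. Compound 1 and compound 3 share one core and differ in a single place: 1,3-thiazol-2-yl in place of pyrimidin-2-yl on a sulfonamide nitrogen. That change produced a 2.2-fold higher number from compound 3 to compound 1 (0.34 log units; beyond the scatter). Compound 2 is built on a different core; the difference between the two cores is not broken down here, and the numbers of compound 2 and compound 1 sit within the scatter of each other.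

Compound 4 `O=c1c(CNc2ccc(S(=O)(=O)Nc3nccs3)cc2)coc2ccccc12` has not been measured. It stands to compound 2 as compound 1 stands to compound 3: 1,3-thiazol-2-yl in place of pyrimidin-2-yl on a sulfonamide nitrogen. The place is described in the same words for both pairs, so this is the same change. Given that the earlier step read a 2.2-fold higher number from compound 3 to compound 1 (0.34 log units; beyond the scatter), a step of similar size is expected here, a 1.6-fold higher number from compound 2 to compound 4 (0.22 log units; within the scatter), with some doubt since the core is different. Compound 4 is therefore expected to give 140000 nM in this assay, most likely between 60000 nM and 300000 nM.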

Compound 4, half-maximal inhibitory concentration: 25600 nM
Beside the measured number, compound 4's estimate is 5.5-fold (0.74 log units) above it; the whole stated range lies above it.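

In this assay the swap of pyrimidin-2-yl for 1,3-thiazol-2-yl on a sulfonamide nitrogen gave a 3.3-fold lower number from compound 2 to compound 4 (0.52 log units; beyond the scatter) on the core of compound 2, the opposite direction to the earlier pair. The same change thus did not carry over from one core to the other, and the two steps truly differ: the same change on two cores in this assay, a 2.2-fold higher number (0.34 log units; beyond the scatter) from compound 3 to compound 1 and a 3.3-fold lower number (0.52 log units; beyond the scatter) from compound 2 to compound 4, 7.3-fold (0.86 log units) apart, beyond the scatter of two such steps. This shows that, in this series, a step read on one core was a poor guide to the same step on the other, but two pairs do not show what in the cores makes the steps part, and they give no rule for any further core.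

The compounds shown carry only these two rings on the sulfonamide nitrogen, so it remains open how a pyridin-2-yl ring or a plain methyl group in that place would read on either core. Also open, on these data alone, is which direction the swap would take on a third core.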